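Replacing the Formyl End with Carboxy

This account rests on a few compounds, and the source may have more. Where it says the series, first, only, none or still open, it means among the compounds named here.

compound 1 `CCCC(=O)CC/C=C/C=C/C#CC#C/C=C/COC(C)=O`: 21600 nM
compound 2 `CCCC(=O)CC/C=C/C=C/C#CC#C/C=C/COC(=O)CCl`: 26900 nM
compound 3 `CCCC(=O)CC/C=C/C=C/C#CC#C/C=C/C=O`: 5900 nM

In a functional assay on MCF7 cells (Homo sapiens) for cytotoxicity, read by sulforhodamine B assay, with a stated time of 96 h (on this read-out higher numbers stand for an effect only at larger amounts of compound and lower numbers for an effect already at smaller amounts), compound 3 gives the lowest of the three numbers, so it acts at the smallest amounts. Compound 4 `CCCC(=O)CC/C=C/C=C/C#CC#C/C=C/C(=O)O` has hydroxy in place of hydrogen on a carbonyl carbon, turning formyl into carboxy: hydroxy in place of hydrogen on a carbonyl carbon. Going by the values given here, no measured step makes this exact change. The closest are a 3.7-fold lower number from compound 1 to compound 3 (0.56 log units; beyond the scatter) and a 4.6-fold lower number from compound 2 to compound 3 (0.66 log units; beyond the scatter), both ending at the formyl compound. Moving away from formyl may therefore lose that modest advantage, so a modest rise is expected: a 3.4-fold higher number from compound 3 to compound 4 (0.53 log units; beyond the scatter). For compound 4 the estimated value is 20000 nM, with an expected range of 7000 nM to 60000 nM.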

Compound 4, half-maximal effective concentration: > 30000 nM
Compound 4: no number, only a limit; the forecaster's own chance of this, stated with the estimate: 20%; middle value at least 1.5-fold (0.17 log units) away from the limit.
By their numbers in this assay, from the lowest: compound 3; then compounds 1 and 2 (each within the scatter of the next). At a limit, above all of these: compound 4.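

Going by these compounds alone, on this carbonyl carbon, hydroxy in place of hydrogen turns formyl into carboxy and gives an at least 5.0-fold higher number from compound 3 to compound 4 (0.70 log units; beyond the scatter), so even one added oxygen here matters, which the earlier steps, all made at the acetoxymethyl end, could not show. Carboxy in place of acetoxymethyl gives an at least 1.3-fold higher number from compound 1 to compound 4 (0.14 log units; that floor lies within the scatter), and carboxy in place of (((chloromethyl)carbonyl)oxy)methyl gives an at least 1.1-fold higher number from compound 2 to compound 4 (0.04 log units; that floor lies within the scatter), so the full size of these two steps stays unknown. Compound 4 has no number, only a limit of the assay: the limit of > 30000 nM in this assay, at which 1 of the 4 values shown sits.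

From the compounds shown here alone, it remains open whether a methyl ester or an amide on this carbonyl carbon would stay close to compound 3 or fall with compound 4.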